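A few compounds are considered here, and "the series" means these few. Any claim that something is new, unique, unknown or untested is made for them only; others in the source may bear on it.

Of the compounds shown here, three built on one shared core have been tested in a functional assay on A549 cells (Homo sapiens) for cytotoxicity, read by MTT assay, with a stated time of 72 h; a lower number here means a stronger inhibitor, a higher number a weaker inhibitor. Compound 1 `CN(C)CCn1cnnc1-c1cc(Oc2ccc(NC(=O)N/N=C/c3ccc(Cl)cc3Cl)cc2F)ccn1` gives 810 nM, the lowest of the three numbers, though the number for compound 2 lies within the scatter of it. Compound 2 `CN(C)CCn1cnnc1-c1cc(Oc2ccc(NC(=O)N/N=C/c3c[nH]c4ccccc34)cc2F)ccn1` gives 820 nM, and compound 3 `COc1ccc(/C=N/NC(=O)Nc2ccc(Oc3ccnc(-c4nncn4CCN(C)C)c3)c(F)c2)c(OC)c1` gives 2820 nM. The step of a 1.0-fold higher number from compound 1 to compound 2 (0.01 log units; within the scatter) is within the scatter, whereas the step of a 3.5-fold higher number from compound 1 to compound 3 (0.54 log units; beyond the scatter) is a modest rise, and the step of a 3.4-fold higher number from compound 2 to compound 3 (0.54 log units; beyond the scatter) is of the same size.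

Compound 4 `CN(C)CCn1cnnc1-c1cc(Oc2ccc(NC(=O)N/N=C/c3ccc(O)cc3)cc2F)ccn1` has not yet been measured. It differs from compound 1 in one place: 4-hydroxyphenyl in place of 2,4-dichlorophenyl on a carbon with a double bond to nitrogen. Both measured steps from compound 1 exchange the same 2,4-dichlorophenyl group at the same carbon and so bear on this change: the step of a 1.0-fold higher number from compound 1 to compound 2 (0.01 log units; within the scatter) was flat, the step of a 3.5-fold higher number from compound 1 to compound 3 (0.54 log units; beyond the scatter) modest. The incoming 4-hydroxyphenyl, with one hydrogen-bond donor and one hydrogen-bond acceptor, is closer to the second case, so a modest rise in this assay is expected, about a 2.0-fold higher number from compound 1 to compound 4 (0.30 log units; within the scatter). Compound 4 is therefore estimated at 1600 nM, within a range from 600 nM to 4500 nM.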

Compound 4, half-maximal inhibitory concentration: 3560 nM
Compound 4: middle estimate off by 2.2-fold (0.35 log units), on the low side; measured number inside the range.
By their numbers in this assay, from the lowest: compounds 1 and 2 (each within the scatter of the next); then compounds 3 and 4 (each within the scatter of the next).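

In this assay, placing 4-hydroxyphenyl on this carbon gives a 4.4-fold higher number from compound 1 to compound 4 (0.64 log units; beyond the scatter) and, against the indole, a 4.3-fold higher number from compound 2 to compound 4 (0.64 log units; beyond the scatter). Replacing 2,4-dimethoxyphenyl with 4-hydroxyphenyl gives a 1.3-fold higher number from compound 3 to compound 4 (0.10 log units; within the scatter), so the two phenyl groups carrying oxygen now form one level, while 2,4-dichlorophenyl and 1H-indol-3-yl form a lower one, with no compound shown going against this split. Going by these compounds alone, the earlier compounds held only one oxygen-bearing group, so this grouping could not be seen until now, and no measurement given here explains it.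

From the compounds shown here alone, it remains open whether the higher numbers follow from the oxygen-bearing groups or from the loss of the two chlorines. A plain phenyl, a phenyl with one chlorine or a phenyl carrying an amine would help separate these two readings.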